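The source may report more compounds than this note shows. Statements on the series, on what has been measured and on what is new or still open speak of the compounds shown alone.

Compound 1 `COc1cc(/C=C/C(=O)c2cccc(-n3cc(-c4ccccc4)[nH]c3=O)c2)cc(OC)c1OC`: in a functional assay on U-251 cells (Homo sapiens) for inhibition (a higher number here means a weaker inhibitor of growth, a lower number a stronger inhibitor of growth), compound 1 gives 630 nM.
Compound 2 `COc1ccc(-c2cn(-c3cccc(C(=O)/C=C/c4cc(OC)c(OC)c(OC)c4)c3)c(=O)[nH]2)cc1`: in this assay compound 2 gives 880 nM.

Compound 2 stands at the higher of the two numbers, but the gap to compound 1 is small: a 1.4-fold higher number from compound 1 to compound 2 (0.15 log units; within the scatter). That step, a methoxy in place of hydrogen on the aromatic ring hanging from the shared core, is the only measured one, and it stayed within the scatter.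

Compound 3 `COc1cc(/C=C/C(=O)c2cccc(-n3cc(-c4cc(OC)c(OC)c(OC)c4)[nH]c3=O)c2)cc(OC)c1OC` carries a larger change at that same ring: 3,4,5-trimethoxyphenyl in place of 4-methoxyphenyl on an aromatic carbon. For the measured compounds named here, no measured step covers the two further methoxy groups. Going by the values given here, the one step that bears on it, from compound 1 to compound 2, points to little effect from methoxy groups on that ring. Compound 3 is therefore expected to move by a 1.1-fold higher number from compound 2 to compound 3 (0.06 log units; within the scatter), not beyond the scatter. The estimate for compound 3 in this assay is 1000 nM, with a range from 400 nM to 2500 nM.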

Compound 3, concentration for 50% growth inhibition: 1230 nM
Compound 3: the middle estimate sits 1.2-fold (0.09 log units) below what was measured; measured number inside the range.
By their numbers in this assay, from the lowest: compounds 1, 2 and 3 (each within the scatter of the next).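

In this assay, the two further methoxy groups of the 3,4,5-trimethoxyphenyl group, which has 12 heavy atoms against 8 in 4-methoxyphenyl, give a small step (a 1.4-fold higher number from compound 2 to compound 3 (0.15 log units; within the scatter)). The widest change shown at this position, 3,4,5-trimethoxyphenyl in place of plain phenyl, also stays small (a 2.0-fold higher number from compound 1 to compound 3 (0.29 log units; within the scatter)), so this aromatic carbon of the five-membered ring carries a much larger aryl group with no change beyond the scatter, which the single methoxy of compound 2 could not show. No measurement here offers an explanation for this flat result.

All three groups at this position are phenyl rings bearing only hydrogen or methoxy. Going by these compounds, how an amine or a carboxylic acid on that ring would read stays open, as does a longer chain in place of the ring.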